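The source may hold more compounds than are shown below. What is called first, only, known or untested is meant among the compounds shown, and "the series" means these compounds.

Among the compounds with values here, in a functional assay on HeLa cells (Homo sapiens) for inhibition, read by CCK-8 assay, with a stated time of 48 h (on this read-out lower numbers stand for stronger inhibition and higher numbers for weaker inhibition), compound 1 (`O=S(=O)(NCCNC(=S)Nc1cccc(Cl)c1)c1ccc(-c2ccccc2OCc2cccc(O)c2)s1`) gives 10700 nM and compound 2 (`O=[N+]([O-])c1cccc(NC(=S)NCCNS(=O)(=O)c2ccc(-c3ccccc3OCc3cccc(O)c3)s2)c1`) gives 11100 nM in the same read-out, so compound 2 stands level with the only other number at hand. Within the data shown here, the single measured step is a 1.0-fold higher number from compound 1 to compound 2 (0.02 log units; within the scatter) for nitro in place of chloro on an aromatic carbon, and it offers no sizeable shift to carry forward. Compound 3 (`COc1ccc(NC(=O)NCCNS(=O)(=O)c2ccc(-c3ccccc3OCc3cccc(O)c3)s2)cc1`) departs from compound 2 on an amine nitrogen, where a whole group is exchanged: a group of 11 heavy atoms (8 carbon, 1 nitrogen, 2 oxygen; one six-membered aromatic ring of carbon only) in place of a group of 12 heavy atoms (7 carbon, 2 nitrogen, 2 oxygen, 1 sulfur; one six-membered aromatic ring of carbon only), on an amine nitrogen with (4-methoxyphenyl)carbamoyl as the entering group. Among the measured compounds shown here, no measured step covers an exchange of this kind, so the one small step gives only weak guidance and the range must stay wide. With nothing pointing either way, no shift beyond the scatter is expected in this assay for this change. The estimated step is a 1.2-fold higher number from compound 2 to compound 3 (0.07 log units; within the scatter) and it is expected to stay within the scatter. In this assay compound 3 is estimated at 13000 nM with an expected range from 5000 nM to 35000 nM as its outer bounds.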

Compound 3, half-maximal inhibitory concentration: > 20000 nM
Compound 3 gave a limit, no number; the forecaster's own chance of this, stated with the estimate: 10%; middle value at least 1.5-fold (0.18 log units) from the limit.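

Compound 3 gives a limit and not a number in this assay, and both new steps rest on that limit: the limit of > 20000 nM in this assay, at which 1 of the 3 values shown sits.

With (4-methoxyphenyl)carbamoyl entering on the amine nitrogen, the exchange of the whole group gives an at least 1.8-fold higher number from compound 2 to compound 3 (0.25 log units; that floor lies within the scatter), and the same comparison with the chloro compound gives an at least 1.8-fold higher number from compound 1 to compound 3 (0.27 log units; that floor lies within the scatter). On these data alone, both steps are floors, so they show that the read-out here has moved past the range where a number is given, which the nitro-for-chloro exchange on the aromatic carbon did not do, yet neither floor by itself lies beyond the scatter and the true size of the steps stays unknown.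

The exchange replaces the sulfur-bearing group with an oxygen-bearing one and changes the aromatic substituent at the same time, so the compounds shown cannot separate these two changes. As far as these compounds go, it also remains open how a thiocarbonyl group carrying the 4-methoxyphenyl ring, or an amine or a carboxylic acid on that ring, would read in this assay.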